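A few compounds are considered here, and "the series" means these few. Any claim that something is new, unique, unknown or untested is made for them only; others in the source may bear on it.

Among the measured compounds shown here, in a functional assay on HL-60 cells (Homo sapiens) for antiproliferative activity, read by MTT assay, with a stated time of 72 h (on this read-out lower numbers stand for stronger inhibition and higher numbers for weaker inhibition), compound 1 `NC1=NC2(CCSCC2)N(OCCCOc2cccc(Cl)c2)C(N)=N1` gives 260 nM, the lowest of the three numbers so far, while compound 2 `NC1=NC2(CCOCC2)N(OCCCOc2ccccc2Cl)C(N)=N1` gives 660 nM and compound 3 `NC1=NC2(CCOCC2)N(OCCCOc2ccc(Cl)c(Cl)c2)C(N)=N1` gives 1240 nM. Compound 4 `NC1=NC2(CCSCC2)N(OCCCOc2ccc(Cl)cc2)C(N)=N1` keeps the core of compound 1 but has 4-chlorophenyl in place of 3-chlorophenyl on an oxygen on a saturated carbon. For the measured compounds named here, no measured pair tests this exact swap. The closest evidence is a 1.9-fold higher number from compound 2 to compound 3 (0.27 log units; within the scatter), which replaces 2-chlorophenyl with 3,4-dichlorophenyl on a different core and stays within the scatter. A similarly small change is therefore expected in this assay, with no clear direction. The expected step is a 1.3-fold higher number from compound 1 to compound 4 (0.13 log units; within the scatter). Compound 4 is estimated at 350 nM, with an expected range from 130 nM to 900 nM.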

Compound 4, half-maximal inhibitory concentration: 430 nM
Estimate against measurement, compound 4: 1.2-fold (0.09 log units) below; the measured number falls inside the stated range.
By their numbers in this assay, from the lowest: compounds 1, 4, 2 and 3 (each within the scatter of the next, the first and the last beyond it).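

Compound 4 gives the first direct test of this change on the core of compound 1: in this assay, 4-chlorophenyl in place of 3-chlorophenyl gives only a small step (a 1.7-fold higher number from compound 1 to compound 4 (0.22 log units; within the scatter)). The two chlorophenyl groups therefore cannot be told apart on this read-out, and no data at hand bear on why.

Still open, going by these compounds, is whether a methoxy group or an amine in place of the chlorine would shift the number beyond the scatter. On these data alone, it is also open whether a longer chain would do so.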